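Benzyl amine in the oxazolyl ketone series

A few compounds are considered here, and "the series" means these few. Any claim that something is new, unique, unknown or untested is made for them only; others in the source may bear on it.

Compound 3 `CC(C)OC(=O)N1CCC(CCCC(=O)c2ncco2)CC1` holds the lowest number of the three measured compounds in an assay on isolated protein for inhibition of Fatty-acid amide hydrolase 1 (Homo sapiens) (a lower number here means a stronger inhibitor, a higher number a weaker inhibitor), where compound 3 gives 4 nM. Compound 1 `O=C(CCCC1CCN(C(=O)c2ccccc2)CC1)c1ncco1` gives 77 nM and compound 2 `CC(C)S(=O)(=O)N1CCC(CCCC(=O)c2ncco2)CC1` gives 140 nM; the step of a 19-fold lower number from compound 1 to compound 3 (1.28 log units; beyond the scatter) and the step of a 35-fold lower number from compound 2 to compound 3 (1.54 log units; beyond the scatter) both stand well beyond the scatter, whereas the step of a 1.8-fold higher number from compound 1 to compound 2 (0.26 log units; within the scatter) does not.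

Compound 4 `O=C(CCCC1CCN(Cc2ccccc2)CC1)c1ncco1` differs from compound 3 in one place: benzyl in place of isopropoxycarbonyl on an amine nitrogen in a ring. Among the measured compounds shown here, no measured pair swaps the group on the ring nitrogen for one lacking a carbonyl or sulfonyl, so no step covers this change directly. What the measured steps do show is that the isopropoxycarbonyl on the ring nitrogen gives a much lower number than either benzoyl or isopropylsulfonyl, and that those two sit within the scatter of each other. Removing the isopropoxycarbonyl is therefore expected to cost potency in this assay, and the step of a 75-fold higher number from compound 3 to compound 4 (1.88 log units; beyond the scatter) is expected to be large, with a higher number for compound 4.

For compound 4 the estimate in this assay is 300 nM, with a range from 60 nM to 2000 nM.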

Compound 4, half-maximal inhibitory concentration: 315 nM
Compound 4: middle estimate off by 1.1-fold (0.02 log units), on the low side; measured number inside the range.
By their numbers in this assay, from the lowest: compound 3; then compounds 1 and 2 (each within the scatter of the next); then compound 4.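

In this assay, among the compounds shown here, benzyl is the first group on this ring nitrogen that carries neither a carbonyl nor a sulfonyl, and replacing isopropoxycarbonyl with it gives a 79-fold higher number from compound 3 to compound 4 (1.90 log units; beyond the scatter). The same nitrogen tolerates the change far better when the group replaced is benzoyl, with a 4.1-fold higher number from compound 1 to compound 4 (0.61 log units; beyond the scatter), or isopropylsulfonyl, with a 2.3-fold higher number from compound 2 to compound 4 (0.35 log units; beyond the scatter); both steps are modest yet beyond the scatter, so benzyl sits apart from those two groups while most of the span at this position still separates isopropoxycarbonyl from the other three. No measurement here accounts for these differences in the series.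

On these data alone, it remains open whether the low number of compound 3 depends on the isopropyl part or on the oxygen-bearing carbonyl group as a whole, a question that ethoxycarbonyl, tert-butoxycarbonyl, phenoxycarbonyl or dimethylcarbamoyl on the same nitrogen would address. Also open, as far as these compounds go, is how the free ring amine compares, and whether substituents on the phenyl ring of benzyl would shift the number of compound 4 in this assay.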